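From thiophen-3-yl to 3-methylthiophen-2-yl at the double bond

A few compounds are considered here, and "the series" means these few. Any claim that something is new, unique, unknown or untested is made for them only; others in the source may bear on it.

Measured so far in a functional assay on RS4-11 cells (Homo sapiens) for antiproliferative activity, read by MTT assay, with a stated time of 72 h; a lower number here means a stronger inhibitor, a higher number a weaker inhibitor
Compound 1 `C=C(Br)C(=O)Nc1ccc2c(c1)/C(=C\c1sccc1C)C(=O)N2` gives 4 nM
Compound 2 `C=C(Br)C(=O)Nc1ccc2c(c1)/C(=C/c1ccc[nH]1)C(=O)N2` gives 11 nM
Compound 3 `C=C(Br)C(=O)Nc1ccc2c(c1)/C(=C/c1ccsc1)C(=O)N2` gives 190 nM

Compound 3 has the highest number of the three, making it the weakest inhibitor here. Compound 4 `C=C(Br)C(=O)Nc1ccc2c(c1)/C(=C/c1sccc1C)C(=O)N2` has 3-methylthiophen-2-yl in place of thiophen-3-yl on a double-bonded chain carbon bound to a double-bonded ring carbon. For the measured compounds named here, the only measured step at this place is a 17-fold higher number from compound 2 to compound 3 (1.24 log units; beyond the scatter) and it is large, so a change here can move the number far. Compound 1 carries the entering group with the opposite double-bond geometry and gives 4 nM as a pointer only. The expected step is a 4.8-fold lower number from compound 3 to compound 4 (0.68 log units; beyond the scatter) and it points to a lower number. In this assay compound 4 is estimated at 40 nM (from 8 nM to 200 nM).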

Compound 4, half-maximal inhibitory concentration: 0.4 nM
Estimate against measurement, compound 4: 100-fold (2.00 log units) above; measured number below the stated range.
By their numbers in this assay, from the lowest: compound 4; then compound 1; then compound 2; then compound 3.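

In this assay, 3-methylthiophen-2-yl in place of thiophen-3-yl gives a 480-fold lower number from compound 3 to compound 4 (2.68 log units; beyond the scatter), and in place of 1H-pyrrol-2-yl it gives a 28-fold lower number from compound 2 to compound 4 (1.44 log units; beyond the scatter), so this place can move the number further than the earlier step showed. Double-bond geometry matters here as well, since the Z form is favoured with a 10-fold lower number from compound 1 to compound 4 (1.00 log units; beyond the scatter), a step that can rest on configuration alone: the fact that compounds 1 and 4 differ only in the configuration as drawn. As far as these compounds go, what thiophen-2-yl without the methyl would give remains open, so the methyl group and the point of attachment cannot be told apart. From the compounds shown here alone, how 3-ethylthiophen-2-yl would read is also open.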